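Expecting little change from a 3,4-dichlorophenyl swap

This account rests on a few compounds, and the source may have more. Where it says the series, first, only, none or still open, it means among the compounds named here.

In a functional assay on SW-620 cells (Homo sapiens) for cytotoxicity, read by MTT assay, with a stated time of 72 h (on this read-out lower numbers stand for stronger inhibition and higher numbers for weaker inhibition), compound 1 `COc1ccc(/C=C2\CCC/C(=C\c3ccc(Cl)cc3)C2=O)cc1OC` gives 5900 nM and compound 2 `COc1ccccc1/C=C1\CCC/C(=C\c2ccc(OC)c(OC)c2)C1=O` gives 7800 nM. Within the data shown here, these two numbers lie within the usual scatter of each other, so compound 2 stands level with the only other measured compound. Compound 3 `COc1ccc(/C=C2\CCC/C(=C\c3ccc(Cl)c(Cl)c3)C2=O)cc1OC` differs from compound 2 in one place: 3,4-dichlorophenyl in place of 2-methoxyphenyl on a double-bonded chain carbon bound to a double-bonded ring carbon. It carries 3,4-dichlorophenyl in place of 2-methoxyphenyl on a double-bonded chain carbon bound to a double-bonded ring carbon. Among the measured compounds shown here, one measured step bears on this place: a 1.3-fold higher number from compound 1 to compound 2 (0.12 log units; within the scatter), which put 2-methoxyphenyl in place of 4-chlorophenyl and stayed within the scatter. On that single step, no change beyond the scatter is expected in this assay. The expected step is a 1.4-fold lower number from compound 2 to compound 3 (0.15 log units; within the scatter), which also lies within the scatter. For compound 3 the estimated value is 5500 nM, with an expected range of 2200 nM to 13000 nM.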

Compound 3, half-maximal inhibitory concentration: 4000 nM
For compound 3 the middle estimate is 1.4-fold (0.14 log units) above the measured one; the measured number falls inside the stated range.
By their numbers in this assay, from the lowest: compounds 3, 1 and 2 (each within the scatter of the next).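

In this assay, putting 3,4-dichlorophenyl in place of 2-methoxyphenyl on a double-bonded chain carbon bound to a double-bonded ring carbon gives a 2.0-fold lower number from compound 2 to compound 3 (0.29 log units; within the scatter), so a group with no hydrogen-bond acceptor stands level with one that has an acceptor. Compound 3 also allows a second comparison: chloro in place of hydrogen on an aromatic carbon gives a 1.5-fold lower number from compound 1 to compound 3 (0.17 log units; within the scatter), so the added chloro moves the number no further than the scatter. Nothing here offers a measured explanation for these results. The compounds shown leave open whether any group at this place can move the number beyond the scatter. An amine or a carboxylic acid on the aromatic ring, for instance, would test this with a quite different kind of group.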